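The compounds below may be only part of what the source reports. "The series", "measured", "known", "first", "only" and "open" are said of these compounds alone.

Compound 1 `CS(=O)(=O)Nc1cccc2c1CCC2c1ncc[nH]1` gives > 10000 nM in a functional assay on CHO cells for agonist activity at Alpha-1B adrenergic receptor (Homo sapiens), read by FLIPR and calcium flux (on this read-out lower numbers stand for an effect already at smaller amounts and higher numbers for an effect only at larger amounts of compound), which is a limit of the assay rather than a measured number.
Compound 2 `Cc1ccc2c(c1NS(C)(=O)=O)CCC2c1ncc[nH]1` gives > 10000 nM in this assay, likewise only a limit.
Compound 3 `Clc1ccc2c(c1-c1ccn[nH]1)CCC2c1ncc[nH]1` gives > 10000 nM in this assay, again only a limit.

Compound 1 thus stands at the limit of > 10000 nM in this assay, at which 3 of the 3 values shown sit; nothing measured places it higher or lower than compound 2 or compound 3, since every value shown is a limit. Among the compounds with values here, the one step between compounds that differ in a single place, a step that the two limits leave unreadable from compound 1 to compound 2, has both of its ends at that limit, so its size cannot be read.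

Compound 4 `Cc1oncc1-c1cccc2c1CCC2c1ncc[nH]1` differs from compound 1 in one place: 5-methyl-1,2-oxazol-4-yl in place of methanesulfonamido on an aromatic carbon. Within the data shown here, no measured step bears directly on this exchange, and the only measured step, from compound 1 to compound 2, is unreadable. Compound 3 also carries a five-membered aromatic ring on the shared core and still sits at the limit, which gives no indication that such a ring brings the effect into the measurable range.

For compound 4 the expected value in this assay is therefore 15000 nM, within a range of 3000 nM to 60000 nM, and most likely the assay again reports only a limit. The expected step that the limit leaves unreadable from compound 1 to compound 4 is accordingly none that could be read beyond the scatter.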

Compound 4, half-maximal effective concentration: > 10000 nM
Compound 4 gave a limit, no number; the forecaster's own chance of this, stated with the estimate: 75%; the middle value lies beyond the limit too.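

Within the data shown here, the exchange of methanesulfonamido for 5-methyl-1,2-oxazol-4-yl between compound 1 and compound 4 gives no step that can be read, since both compounds end at a limit of the assay rather than a number: the limit of > 10000 nM in this assay, at which 4 of the 4 values shown sit. The compounds shown leave open what change on the shared core, if any, would give a measured number in this assay rather than a limit.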